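A few compounds are considered here, and "the series" means these few. Any claim that something is new, unique, unknown or untested is made for them only; others in the source may bear on it.

Of the compounds shown here, three that share one core have been measured. Compound 1 `COc1cc(NC(C)CCCNC(=O)Nc2ccc(F)cc2)c2ncccc2c1` carries a 4-fluorophenyl group on an amide-type nitrogen. In a functional assay on L1210 cells (Mus musculus) for inhibition, read by MTT assay, with a stated time of 72 h (on this read-out lower numbers stand for stronger inhibition and higher numbers for weaker inhibition), compound 1 gives 18000 nM. Compound 2 `COc1cc(NC(C)CCCNC(=O)NNC(=O)Nc2cccc(F)c2)c2ncccc2c1` differs from compound 1 in a single place: ((3-fluorophenyl)carbamoyl)amino in place of 4-fluorophenyl on an amide-type nitrogen. In this assay compound 2 gives 108000 nM, which is a 6.0-fold higher number from compound 1 to compound 2 (0.78 log units; beyond the scatter). Compound 3 `COc1cc(NC(C)CCCNC(=O)Nc2ccc(C(F)(F)F)cc2)c2ncccc2c1` differs from compound 1 only by trifluoromethyl in place of fluoro on an aromatic carbon. In this assay compound 3 gives 7400 nM, a step of a 2.4-fold lower number from compound 1 to compound 3 (0.39 log units; beyond the scatter), and against compound 2 the step reads a 15-fold lower number from compound 2 to compound 3 (1.16 log units; beyond the scatter). Among these three, compound 2 stands highest.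

Compound 4 `COc1cc(NC(C)CCCNC(=O)NNC(=O)Nc2cccc(C(F)(F)F)c2)c2ncccc2c1` is not yet measured. Within the data shown here, its core is that of compound 2, so the difference from the core of compound 1 is the one already described for compound 2. Compound 4 differs from compound 2 by trifluoromethyl in place of fluoro on an aromatic carbon. Among the measured compounds shown here, this is the same kind of change as the one that turned compound 1 into compound 3, but not the same: in compound 3 the new group sits para to a large group, while in compound 4 it sits meta to a large group. The earlier step of this kind was a 2.4-fold lower number from compound 1 to compound 3 (0.39 log units; beyond the scatter). On that basis, and allowing for the different place, the step from compound 2 to compound 4 is expected to be a 2.2-fold lower number from compound 2 to compound 4 (0.33 log units; beyond the scatter). Compound 4 is therefore estimated at 50000 nM, within a range from 20000 nM to 150000 nM.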

Compound 4, half-maximal inhibitory concentration: 4000 nM
Beside the measured number, compound 4's estimate is 13-fold (1.10 log units) above it, and the stated range ends above it.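

In this assay the swap of fluoro for trifluoromethyl on the aromatic ring gives a 27-fold lower number from compound 2 to compound 4 (1.43 log units; beyond the scatter) and so points the same way as on the core of compound 1, but the size of the step does not carry over from one core to the other: the same change on two cores in this assay, a 2.4-fold lower number (0.39 log units; beyond the scatter) from compound 1 to compound 3 and a 27-fold lower number (1.43 log units; beyond the scatter) from compound 2 to compound 4, 11-fold (1.05 log units) apart, beyond the scatter of two such steps. On these two pairs, the direction of the change held across the cores, while a step measured on one core would have been a poor guide to the size of the step on the other. This does not show why the steps differ, since the two pairs differ in more than the core: in compound 4 the new group sits meta to a large group, whereas in compound 3 it sits at another place on the ring, and two pairs cannot separate these influences.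

From the compounds shown here alone, it remains open whether the larger step belongs to the core of compound 2 or to the place of the group, which pairs with the group at one same place on both cores could settle. Going by these compounds, it is also open whether a chlorine atom, a methyl group or a nitrile at that place on the core of compound 2 would give a step of similar size, or whether this one belongs to trifluoromethyl alone.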